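Swapping pyrrolidin-1-yl in compound 3: lipophilicity outlook

The compounds below may be only part of what the source reports. "The series", "measured", "known", "first", "only" and "open" are said of these compounds alone.

Among the compounds with values here, in a physicochemical assay for lipophilicity, at pH 7.4 (on this read-out lower numbers stand for lower lipophilicity and higher numbers for higher lipophilicity), compound 3 (`CCOc1cc(Cl)c(C(=O)NC(=O)Nc2nc3ccc(CN4CCN(C)CC4)cc3s2)cc1N1CCCC1`) gives 4, the highest of the three numbers so far. Compound 1 (`CCOc1cc(Cl)c(C(=O)NC(=O)Nc2nc3ccc(S(=O)(=O)C4CCN(C)CC4)cc3s2)cc1-n1cccn1`) gives 3 and compound 2 (`Cc1cc(Cl)c(C(=O)NC(=O)Nc2nc3ccc(S(=O)(=O)C4CCN(C)CC4)cc3s2)cc1-n1cccn1`) gives 2.5, both beyond the scatter from compound 3.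

Compound 4 (`CCOc1cc(Cl)c(C(=O)NC(=O)Nc2nc3ccc(CN4CCN(C)CC4)cc3s2)cc1-n1cccn1`) is one change away from compound 3: 1H-pyrazol-1-yl in place of pyrrolidin-1-yl on an aromatic carbon. This places 1H-pyrazol-1-yl in place of pyrrolidin-1-yl on an aromatic carbon, ortho to an ethoxy group and para to a chloro group.

Within the data shown here, the only measured single-place step is a number 0.50 log units lower from compound 1 to compound 2 (beyond the scatter). It is modest and concerns methyl in place of ethoxy, so it does not test this exchange. It serves only as a rough guide to size. Among the measured compounds shown here, no measured pair isolates the exchange itself, which leaves the estimate loose. The 1H-pyrazol-1-yl and ethoxy groups of compound 4 also occur in compound 1, at 3, although the two compounds differ elsewhere. That value points downward from compound 3.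

The expected change, a modest drop beyond the scatter, is a number 0.70 log units lower from compound 3 to compound 4 (beyond the scatter). In this assay, the estimate for compound 4 is 3.3, with an expected range from 2.8 to 3.8.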

Compound 4, distribution coefficient: 3.8
Compound 4: the middle estimate sits 0.50 log units below what was measured; measured number inside the range.
By their numbers in this assay, from the lowest: compound 2; then compound 1; then compounds 4 and 3 (each within the scatter of the next).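

In this assay the exchange at this aromatic carbon, ortho to an ethoxy group and para to a chloro group, now has a direct read: a number 0.20 log units lower from compound 3 to compound 4 (within the scatter) on the (4-methylpiperazin-1-yl)methyl background. On this read-out compound 3 and compound 4 cannot be told apart, even though a five-membered non-aromatic ring with 1 hetero atom gives way to a five-membered aromatic ring with 2 hetero atoms. With 1H-pyrazol-1-yl and ethoxy held constant, the step at the other place, (4-methylpiperazin-1-yl)methyl in place of (1-methylpiperidin-4-yl)sulfonyl, is a number 0.80 log units higher from compound 1 to compound 4 (beyond the scatter) and lies beyond the scatter, so of these two single-place steps only this one registers; no measurement at hand explains either step.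

Going by these compounds, the exchange is read only once, on a single background, so whether compound 1's (1-methylpiperidin-4-yl)sulfonyl background or a methyl in place of the ethoxy group would give the same near-silent step remains open. Also open, on these data alone, is how groups of another kind on this aromatic carbon, such as morpholin-4-yl, a dimethylamino group or a carboxylic acid, would read in this assay against pyrrolidin-1-yl and 1H-pyrazol-1-yl.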